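The source may hold more compounds than are shown below. What is called first, only, known or untested is meant among the compounds shown, and "the series" means these compounds.

Working notes on the series in an ADME assay on L6 cells (Rattus norvegicus) for cytotoxicity; on this read-out higher numbers stand for weaker inhibition and lower numbers for stronger inhibition. Compound 1 `O=C(NCCCn1ccnc1[N+](=O)[O-])c1ccc(C(F)(F)F)cc1` gives 177000 nM, compound 2 `O=[N+]([O-])c1nccn1CCCNS(=O)(=O)c1ccc(C(F)(F)F)cc1` gives 176000 nM, and compound 3 `O=[N+]([O-])c1ncn(CCCNS(=O)(=O)c2ccc(C(F)(F)F)cc2)n1` gives 235000 nM. These three numbers lie within the scatter of one another, so compound 3 stands level with compound 1 and compound 2.

Compound 4 `Cc1ccc(S(=O)(=O)NCCCn2cnc([N+](=O)[O-])n2)cc1` follows from compound 3 by a single change: methyl in place of trifluoromethyl on an aromatic carbon, para to a large group.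

For the measured compounds named here, no measured step changes the trifluoromethyl group, so the data give no direct guide to this change. The nearest evidence is a 1.3-fold higher number from compound 2 to compound 3 (0.13 log units; within the scatter), a replacement elsewhere in the molecule, and it is small. On that basis, no step beyond the scatter is expected in this assay, and no direction can be called with confidence. The estimated step is a 1.1-fold lower number from compound 3 to compound 4 (0.03 log units; within the scatter). For compound 4 the estimated value is 220000 nM, with an expected range from 110000 nM to 400000 nM.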

Compound 4, half-maximal inhibitory concentration: > 307000 nM
Compound 4: only a limit was reported; the forecaster's own chance of this, stated with the estimate: 10%; middle value at least 1.3-fold (0.14 log units) away from the limit.
By their numbers in this assay, from the lowest: compounds 2, 1 and 3 (each within the scatter of the next). At a limit, above all of these: compound 4.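

In this assay the trifluoromethyl position now has its first reading: methyl in place of trifluoromethyl on an aromatic carbon, para to a large group, gives an at least 1.3-fold higher number from compound 3 to compound 4 (0.11 log units; that floor lies within the scatter). Compound 4 stands at a limit of the assay, not at a number: the limit of > 307000 nM in this assay, at which 1 of the 4 values shown sits. From the compounds shown here alone, this change therefore brings no lower number on this read-out, but only the floor of the step can be read, so its true size remains unknown.

The compounds shown leave open how an amine or a carboxylic acid on this aromatic carbon would read, and whether either would bring the number down. They also leave open whether methyl in place of trifluoromethyl would read the same with 2-nitro-1H-imidazol-1-yl on the chain, or with a longer chain.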